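Replacing the aryl ether of compound 3 with a neopentyl ether

The source may hold more compounds than are shown below. What is called first, only, known or untested is meant among the compounds shown, and "the series" means these compounds.

Three compounds have been run in a functional assay on MX1 cells (Homo sapiens) for antiproliferative activity, with a stated time of 72 h; a higher number here means that more compound is needed for the effect, a lower number that less compound is needed. The compound 1 (`Cn1cc(-c2ccccc2Oc2ccccc2)ccc1=O`), which lacks the sulfonamide and the fused core of the others, gives 4800 nM. Compound 2 (`CCS(=O)(=O)Nc1ccc(Oc2ccccc2)c(-c2cn(C)c(=O)c3[nH]ccc23)c1`) gives 14 nM, and compound 3 (`CCS(=O)(=O)Nc1ccc(Oc2ccc(C#N)cc2)c(-c2cn(C)c(=O)c3[nH]ccc23)c1`) gives 17 nM. Within the data shown here, the only single-point step measured is a 1.2-fold higher number from compound 2 to compound 3 (0.08 log units; within the scatter). Compound 3 thus sits with compound 2 at the potent end of the set; the two are within the scatter of each other, and both are far from compound 1.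

Compound 4 (`CCS(=O)(=O)Nc1ccc(OCC(C)(C)C)c(-c2cn(C)c(=O)c3[nH]ccc23)c1`) carries neopentyl in place of 4-cyanophenyl on an oxygen on an aromatic ring. Among the measured compounds shown here, no measured step bears directly on this change: the step from compound 2 to compound 3 alters only a substituent on the aryl ether ring and stays within the scatter, whereas compound 4 removes that ring altogether in favour of a branched alkyl group. The set gives no evidence that the aryl ether is needed, but also none that it is dispensable. For compound 4 in this assay, the expected step is a 2.6-fold higher number from compound 3 to compound 4 (0.42 log units; beyond the scatter), leaning toward a somewhat higher number, with the estimate for compound 4 being 45 nM within a range of 10 nM to 250 nM.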

Compound 4, half-maximal effective concentration: 77 nM
Estimate against measurement, compound 4: 1.7-fold (0.23 log units) below, and the stated range covers the measured number.
By their numbers in this assay, from the lowest: compounds 2 and 3 (each within the scatter of the next); then compound 4; then compound 1.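

In this assay the group on the oxygen on an aromatic ring proves able to give up its aromatic ring and keep activity, at a modest cost: neopentyl in place of 4-cyanophenyl gives (a 4.5-fold higher number from compound 3 to compound 4 (0.66 log units; beyond the scatter)), and neopentyl in place of phenyl gives (a 5.5-fold higher number from compound 2 to compound 4 (0.74 log units; beyond the scatter)), both beyond the scatter. Among these compounds, the earlier step between the two aryl ethers stayed within the scatter, so this is the first change at this position that shifts the number, and it does so from either aryl ether. No measurement here explains the shift or separates the contribution of the lost aromatic ring from that of the neopentyl branching.

Still open, as far as these compounds go, is whether a cyclohexyl group on the same oxygen would behave like the aryl ethers or like the neopentyl ether, which would show whether the aromatic ring itself or simply a ring is what counts. Also open, from the compounds shown here alone, is how a longer straight chain, or a chain ending in an amine, would compare with neopentyl at this position.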